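One Carbon More on the Side Chain

The source may hold more compounds than are shown below. What is called first, only, known or untested is meant among the compounds shown, and "the series" means these compounds.

Of the compounds shown here, two have so far been measured in an assay for inhibition of Nitric oxide synthase, inducible (Homo sapiens), read by scintillation counting, with a stated time of 30 min, tested at 1 mM; on this read-out higher numbers stand for more inhibition at the one concentration tested (going by the name of the read-out) and lower numbers for less inhibition. Compound 1, `CNC(=S)NCCC(=O)c1cc(OC)ccc1N`, gives 78.2% in this assay. Compound 2, `CNC(=S)NCCC(O)c1ccccc1N`, gives 20.7% in this assay. For the measured compounds named here, of these two numbers, compound 2 stands lowest; its only neighbour is compound 1, whose number lies higher by a gap that is beyond the usual scatter of this assay. Going by the values given here, the two structures differ in more than one place, so no single step between them can be read off.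

Compound 3, `CCNC(=S)NCCC(O)c1ccccc1N`, has not yet been measured. It differs from compound 2 in one place only: methyl in place of hydrogen on a saturated chain carbon bound to an amide-type nitrogen. Cut one bond further out, the same difference reads methyl to ethyl, or methylamino to ethylamino.

Among the compounds with values here, with no measured single-place step among the known compounds, there is nothing to set the size of this step against. A change this small is expected to move the number little: the step from compound 2 to compound 3 in this assay is estimated as a number 2.3 percentage points higher from compound 2 to compound 3 (within the scatter), not beyond the scatter. Compound 3 is therefore expected to give about 23% in this assay, within a range from 5% to 42%.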

Compound 3, a percentage reported as inhibition, at one concentration (the size of the read-out at that concentration, not a potency): 19.4%
Compound 3: the middle estimate sits 3.6 percentage points above what was measured, within the range that was stated.
By their numbers in this assay, from the lowest: compounds 3 and 2 (each within the scatter of the next); then compound 1.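

In this assay the step of a number 1.3 percentage points lower from compound 2 to compound 3 (within the scatter) is the first single-place step that can be read among these compounds. At this place, on a saturated chain carbon bound to an amide-type nitrogen, methyl in place of hydrogen, which turns methylamino into ethylamino, gives no difference that this read-out can separate from the usual scatter at the one concentration tested. No measurement on hand offers an explanation for this result.

One added carbon says nothing yet about larger groups at the same place, such as a propyl or butyl chain, a branched isopropyl group or a benzyl group, any of which could give a number that stays close to these two or one that moves well away from them. Also open, going by these compounds, is whether the same change from methyl to ethyl would read the same way on the core of compound 1, where the surroundings of the side chain differ and where only a matched pair of compounds could answer the question.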